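Oxazole hydroxamates: bromo substitution on the aryl ring

The source may hold more compounds than are shown below. What is called first, only, known or untested is meant among the compounds shown, and "the series" means these compounds.

Compound 1 `O=C(NO)c1coc(-c2ccccc2)n1` is the reference point of this small set. In an assay on isolated protein for inhibition of protein deacetylase HDAC6 (Homo sapiens), read by fluorescence, with a stated time of 90 min (a lower number here means a stronger inhibitor, a higher number a weaker inhibitor), compound 1 gives 270 nM, the lowest number among the three measured compounds. Compound 3 `O=C(NO)c1coc(-c2cccs2)n1` gives 311 nM in this assay, a number within the scatter of that of compound 1, so no order between the two is claimed. Within the data shown here, compound 2 `O=C(NO)c1coc(C(c2ccccc2)c2ccccc2)n1` gives 9370 nM in this assay, a number beyond the scatter from that of compound 1; compound 2 differs from compound 1 in more than one place, so no single step is computed for that pair.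

Compound 4 `O=C(NO)c1coc(-c2ccccc2Br)n1` is not yet measured. It differs from compound 1 by bromo in place of hydrogen on an aromatic carbon. Among the measured compounds shown here, no measured pair in the set shows this kind of change, so the expectation rests on the position of compound 1 alone. A small step toward a higher number, possibly within the scatter, is expected: a 1.9-fold higher number from compound 1 to compound 4 (0.27 log units; within the scatter). For compound 4 the estimated value in this assay is 500 nM, with an expected range from 150 nM to 2000 nM.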

Compound 4, half-maximal inhibitory concentration: 2180 nM
For compound 4 the middle estimate is 4.4-fold (0.64 log units) below the measured one; measured number outside the range, above it.
By their numbers in this assay, from the lowest: compounds 1 and 3 (each within the scatter of the next); then compound 4; then compound 2.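

In this assay, among these compounds, bromo in place of hydrogen on an aromatic carbon of the six-membered aromatic ring, ortho to a group of 9 heavy atoms, gives an 8.1-fold higher number from compound 1 to compound 4 (0.91 log units; beyond the scatter) as the first single-place change in this set. The earlier compounds shown here gave no reading at this carbon; this step shows that the number is sensitive here, with one bromine atom enough to take compound 4 clearly away from compound 1. No evidence is available that bears on what lies behind this step.

Still open, from the compounds shown here alone, is whether this step is particular to bromo or would also appear with fluoro, methyl or methoxy on the same carbon. Also open, going by these compounds, is how bromo behaves on the other carbons of this ring, and whether an amine there would follow it.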